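The source may report more compounds than this note shows. Statements on the series, on what has been measured and on what is new or still open speak of the compounds shown alone.

Two compounds share a core and differ only in the chain on the ester side. Compound 1 `CCOC(=O)CC(=O)Nc1c(C(C)C)cccc1C(C)C` carries the short ethyl ester and in an assay on microsomes from intestine for inhibition of acyl-CoA:cholesterol acyltransferase (Oryctolagus cuniculus) (on this read-out higher numbers stand for weaker inhibition and lower numbers for stronger inhibition), gives 1800 nM. Compound 2 `CCCCCCCCCCOC(=O)CC(=O)Nc1c(C(C)C)cccc1C(C)C` carries the long decyl ester and in this assay gives 53 nM. Among the compounds with values here, the change between them is the step of a 34-fold lower number from compound 1 to compound 2 (1.53 log units; beyond the scatter), so compound 2 stands at the lower of the two numbers and compound 1 is its only neighbour.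

Compound 3 `CCCCCCCCCCCCOC(=O)CC(=O)Nc1c(C(C)C)cccc1C(C)C` has not yet been measured. It differs from compound 2 in one place: ethyl in place of hydrogen on a saturated chain carbon, ten or more bonds along the chain from an oxygen next to a carbonyl group. Within the data shown here, the only measured step that bears on this is the one from compound 1 to compound 2, which lengthened the same chain by a much larger piece and brought a large drop in this assay. Lengthening the chain by a further small piece is therefore expected to give at most a modest further drop, possibly nothing beyond the scatter, as a step of a 1.5-fold lower number from compound 2 to compound 3 (0.18 log units; within the scatter). Compound 3 is estimated at 35 nM in this assay, within a range from 12 nM to 110 nM.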

Compound 3, half-maximal inhibitory concentration: 11 nM
Compound 3: middle estimate off by 3.2-fold (0.50 log units), on the high side; measured number outside the range, below it.
By their numbers in this assay, from the lowest: compound 3; then compound 2; then compound 1.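

The ester chain still matters beyond the decyl of compound 2: in this assay, ethyl in place of hydrogen on a saturated chain carbon, ten or more bonds along the chain from an oxygen next to a carbonyl group, gives a 4.8-fold lower number from compound 2 to compound 3 (0.68 log units; beyond the scatter) and this step lies beyond the scatter. So even a small addition this far out along the chain moves the number, and the lower end of the series had not yet been reached at compound 2. Taken as one change, the whole lengthening of the ester chain gives a 160-fold lower number from compound 1 to compound 3 (2.21 log units; beyond the scatter) and, within these three compounds, each longer chain goes with a lower number and no compound goes against this, though nothing at hand gives a reason for these steps.

A longer chain could continue this fall, level off or reverse it, and the three compounds cannot tell which. They also leave open what an amine or a carboxylic acid at the far end of the chain would do to the number.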